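The compounds below may be only part of what the source reports. "The series", "measured", "known", "first", "only" and "open" are said of these compounds alone.

In a functional assay on MT4 cells (Homo sapiens) for cytotoxicity, read by MTT assay (a lower number here means that less compound is tolerated, a higher number that more compound is tolerated), compound 2, `Cc1c(O)nc(SCc2ccccc2)nc1Cc1c(Cl)cccc1Cl`, gives only a limit of the assay, > 64000 nM. Compound 1, `Cc1c(O)nc(S(=O)(=O)Cc2ccc(Br)cc2)nc1Cc1c(Cl)cccc1Cl`, likewise reaches only a limit in this assay, > 50000 nM. Among the measured compounds shown here, compound 3, `COc1ccc(CS(=O)(=O)c2nc(O)c(C)c(Cc3c(Cl)cccc3Cl)n2)cc1`, is the one compound of the three with a measured number in this assay, 2800 nM. For the measured compounds named here, the only step between compounds differing in one place runs from compound 1 to compound 3, methoxy in place of bromo on an aromatic carbon, and it is an at least 17-fold lower number from compound 1 to compound 3 (1.25 log units; beyond the scatter); it starts from the limit (the limit of > 50000 nM in this assay, at which 1 of the 3 values shown sits), so its true size is unknown. Compound 4, `Cc1c(O)nc(SCc2ccc(C#N)cc2)nc1Cc1c(Cl)cccc1Cl`, differs from compound 2 by cyano in place of hydrogen on an aromatic carbon. Going by the values given here, no measured step concerns a cyano group, and compound 2 differs from compounds 1 and 3 in more than one place, so the step from compound 1 to compound 3 bears on the change only in showing that a substituent swap at the same place of the benzyl ring can move this assay far. Compound 4 is therefore expected to sit near the limit again, estimated at 45000 nM with a range from 9000 nM to 64000 nM, which amounts to an expected step of an at least 1.4-fold lower number from compound 2 to compound 4 (0.15 log units; that floor lies within the scatter).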

Compound 4, half-maximal cytotoxic concentration: > 60000 nM
Compound 4: a limit, no number (the forecaster's own chance of this, stated with the estimate: 60%); at least 1.3-fold (0.12 log units) between middle value and limit.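

In this assay compound 4 gives > 60000 nM, a limit and not a number. Compound 2 also stands at a limit, so no step can be read between compound 2 and compound 4. The compounds shown leave open whether cyano in place of hydrogen changes this read-out at all.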